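The source may hold more compounds than are shown below. What is called first, only, known or untested is meant among the compounds shown, and "the series" means these compounds.

Measured compounds:
compound 1 `COc1ccc(-c2csc(N)c2C(=O)OCc2cccc(C)c2)cc1OC` — 67%
compound 2 `COc1ccc(-c2csc(N)c2C(=O)OCc2ccncc2)cc1OC` — 53%
compound 3 `COc1ccc(-c2csc(N)c2C(=O)NCc2ccccc2)cc1OC` — 43%

All three share one core and differ only in the group on the carbonyl carbon. In an assay on isolated protein for inhibition of protein kinase C zeta type (Homo sapiens), with stated times of 1 h and 2.5 min, tested at 30 uM (on this read-out lower numbers stand for less inhibition and higher numbers for more inhibition at the one concentration tested (going by the name of the read-out)), the number for compound 3 sits at the bottom of the three, but the gap a number 10 percentage points lower from compound 2 to compound 3 (within the scatter) is within the scatter, so these two are not separated; only compound 1 stands clearly apart a number 24 percentage points lower from compound 1 to compound 3 (beyond the scatter), and within the esters the change a number 14 percentage points lower from compound 1 to compound 2 (beyond the scatter) also pointed downward.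

Compound 4 `COc1ccc(-c2csc(N)c2C(=O)O)cc1OC` is not yet measured. The change from compound 3 is hydroxy in place of benzylamino on a carbonyl carbon. For the measured compounds named here, no measured step removes the whole benzylamino group; the nearest guides are the steps that shrank or altered what hangs on the carbonyl, a number 24 percentage points lower from compound 1 to compound 3 (beyond the scatter) and a number 14 percentage points lower from compound 1 to compound 2 (beyond the scatter), both modest and downward. A further downward step of similar size, possibly toward very little inhibition, is expected, with considerable uncertainty. Compound 4 is therefore estimated at 20% (from 0% to 45%). The step expected is a number 23 percentage points lower from compound 3 to compound 4 (beyond the scatter).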

Compound 4, a percentage reported as inhibition, at one concentration (the size of the read-out at that concentration, not a potency): 65%
Compound 4: middle estimate off by 45 percentage points, on the low side; the measured number lies above the stated range.
By their numbers in this assay, from the lowest: compounds 3 and 2 (each within the scatter of the next); then compounds 4 and 1 (each within the scatter of the next).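

In this assay, for the compounds shown here, the hydroxy on the carbonyl carbon reverses the downward trend among the earlier compounds: the change gives a number 22 percentage points higher from compound 3 to compound 4 (beyond the scatter), so the benzylamino group, with its 8 heavy atoms and aromatic ring, is not needed for inhibition at this position. Among the groups on the oxygen next to a carbonyl group, hydrogen in place of (pyridin-4-yl)methyl gives a number 12 percentage points higher from compound 2 to compound 4 (beyond the scatter), while hydrogen in place of 3-methylbenzyl gives a number 2 percentage points lower from compound 1 to compound 4 (within the scatter), so a group as large as 3-methylbenzyl is not required to reach this level of inhibition. Nothing measured here accounts for these steps.

Still open, from the compounds shown here alone, is whether a small methyl ester would read with compound 4 or fall nearer compound 2. Also open, going by these compounds, is whether a primary amide, which lacks the benzyl group, would remain as low as compound 3 or read with compound 4.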